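Amide variation: expected recovery from compound 3 to compound 4

The source may report more compounds than this note shows. Statements on the series, on what has been measured and on what is new or still open speak of the compounds shown alone.

Compound 3 `COc1cc2c(cc1OC)C(CC(=O)N1CCOCC1)CC2` gives 14% in a functional assay on the whole organism (strain Wistar) for inhibition, with Rattus norvegicus as the target, read by paw edema, with stated times of 60 min and 2 h, at a dose of 100 mg/kg by the oral route (on this read-out higher numbers stand for more inhibition at the one dose given (going by the name of the read-out) and lower numbers for less inhibition), the lowest of the three numbers measured. Compound 1 `COc1cc2c(cc1OC)C(CC(=O)N(C)C)CC2` gives 36% and compound 2 `CCCCCNC(=O)CC1CCc2cc(OC)c(OC)cc21` gives 34% in this assay. The step of a number 2 percentage points lower from compound 1 to compound 2 (within the scatter) lies within the scatter, whereas a number 22 percentage points lower from compound 1 to compound 3 (beyond the scatter) and a number 20 percentage points lower from compound 2 to compound 3 (beyond the scatter) both lie beyond it. Compound 4 `COc1cc2c(cc1OC)C(CC(=O)NCCO)CC2` carries the change ((2-hydroxyethyl)amino in place of morpholin-4-yl on a carbonyl carbon). Going by the values given here, the steps that bear on it are those placing morpholin-4-yl on the carbonyl carbon, a number 22 percentage points lower from compound 1 to compound 3 (beyond the scatter) and a number 20 percentage points lower from compound 2 to compound 3 (beyond the scatter); reversing that change is expected to raise the number by a modest amount because a number 20 percentage points lower from compound 2 to compound 3 (beyond the scatter) ran the other way. Compound 4 is therefore estimated at 30%, with a range from 15% to 45%. The expected step is a number 16 percentage points higher from compound 3 to compound 4 (beyond the scatter).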

Compound 4, a percentage reported as inhibition, in the whole organism at one dose (the size of the read-out at that dose, not a potency): 0%
For compound 4 the middle estimate is 30 percentage points above the measured one, outside the stated range (below it).
By their numbers in this assay, from the lowest: compound 4; then compound 3; then compounds 2 and 1 (each within the scatter of the next).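

On the carbonyl carbon, (2-hydroxyethyl)amino in place of morpholin-4-yl gives a number 14 percentage points lower from compound 3 to compound 4 (beyond the scatter), so removing the ring does not bring the number back. Hydroxy in place of propyl on the chain gives a number 34 percentage points lower from compound 2 to compound 4 (beyond the scatter), and (2-hydroxyethyl)amino in place of dimethylamino gives a number 36 percentage points lower from compound 1 to compound 4 (beyond the scatter). Among these four compounds, the two amide groups containing oxygen, in compound 3 and compound 4, give the lowest numbers.

No available evidence accounts for these drops. On these data alone, whether the hydroxy itself or merely the oxygen in the chain matters remains open, and (2-methoxyethyl)amino or (3-hydroxypropyl)amino on the carbonyl carbon would separate the two.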